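Swapping the aryl group on a fused bicyclic core

The source may report more compounds than this note shows. Statements on the series, on what has been measured and on what is new or still open speak of the compounds shown alone.

Compound 1 `N#CC1=C(N)N(c2ccc(S(N)(=O)=O)cc2)C2=C(C(=O)CCC2)C1c1cccc([N+](=O)[O-])c1`: 50%
Compound 2 `Cc1ccoc1C1C(C#N)=C(N)N(c2ccc(S(N)(=O)=O)cc2)C2=C1C(=O)CCC2`: 10%

Both compounds were tested in a functional assay on Ehrlich cells (Mus musculus) for antiproliferative activity, read by trypan blue exclusion, with a stated time of 2 h, tested at 25 ug/mL; on this read-out higher numbers stand for a stronger effect at the one concentration tested and lower numbers for a weaker effect. On these two numbers compound 1 stands highest; its nearest neighbour is compound 2, reached by a number 40 percentage points lower from compound 1 to compound 2 (beyond the scatter), a change made where 3-methylfuran-2-yl took the place of 3-nitrophenyl on a saturated ring carbon.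

Compound 3 `N#CC1=C(N)N(c2ccc(S(N)(=O)=O)cc2)C2=C(C(=O)CCC2)C1c1cccs1` has not yet been measured in this assay. It differs from compound 1 in one place: thiophen-2-yl in place of 3-nitrophenyl on a saturated ring carbon. Going by the values given here, the only measured step that bears on this is a number 40 percentage points lower from compound 1 to compound 2 (beyond the scatter), in which the same 3-nitrophenyl group left and a five-membered heteroaryl group entered, with a large fall in the read-out. Because of a number 40 percentage points lower from compound 1 to compound 2 (beyond the scatter) a fall is also expected for compound 3, though one step gives only a rough size. The step expected is a number 25 percentage points lower from compound 1 to compound 3 (beyond the scatter). Compound 3 is therefore estimated at 25%, expected to lie between 5% and 50%.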

Compound 3, a percentage reported as activity, at one concentration (the size of the read-out at that concentration, not a potency): 80%
Compound 3: the middle estimate sits 55 percentage points below what was measured; the measured number lies above the stated range.
By their numbers in this assay, from the lowest: compound 2; then compound 1; then compound 3.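

At this saturated ring carbon, a five-membered aromatic ring does not by itself lower the read-out in this assay: with thiophen-2-yl in place of 3-nitrophenyl, there is a number 30 percentage points higher from compound 1 to compound 3 (beyond the scatter). The two five-membered groups also end far apart, with a number 70 percentage points higher from compound 2 to compound 3 (beyond the scatter), so ring size alone does not set the read-out at this position, and the choice of ring and its substituent matters. Nothing available here explains the difference between these groups.

Thiophen-2-yl and 3-methylfuran-2-yl differ both in the ring hetero atom, sulfur against oxygen, and in the methyl group, so the compounds shown cannot tell which of these changes accounts for the gap. Plain furan-2-yl or 3-methylthiophen-2-yl at this carbon would separate the two, and a non-aromatic group such as cyclohexyl would test whether an aromatic ring is needed here at all.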